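Furan-2-yl Ketone Variant in a Weakly Cytotoxic Series

The source may report more compounds than this note shows. Statements on the series, on what has been measured and on what is new or still open speak of the compounds shown alone.

Within the data shown here, compound 1 `COc1cc(-c2nnc3n2NC(c2ccco2)C(C(=O)c2ccc(Cl)cc2)S3)cc(OC)c1OC` is the only member of this small set to return a number in a functional assay on A549 cells (Homo sapiens) for cytotoxicity, read by MTT assay, with a stated time of 48 h; a higher number here means a weaker inhibitor, a lower number a stronger inhibitor: compound 1 gives 51400 nM. Compound 2 `COc1cc(-c2nnc3n2NC(c2ccco2)C(C(=O)C2CC2)S3)cc(OC)c1OC`, which carries cyclopropyl in place of 4-chlorophenyl on a carbonyl carbon, comes back only as a limit of the assay, and compound 2 gives > 100000 nM. Compound 3 `COc1cc(C(=O)C2Sc3nnc(-c4cc(OC)c(OC)c(OC)c4)n3NC2c2cccs2)cc(OC)c1OC` is likewise reported only as a limit, and compound 3 gives > 100000 nM.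

Among the measured compounds shown here, the single measured step, an at least 1.9-fold higher number from compound 1 to compound 2 (0.28 log units; that floor lies within the scatter), alters the substituent on the carbonyl carbon and lands on (the limit of > 100000 nM in this assay, at which 2 of the 3 values shown sit), so its true size is not known beyond its floor. Compound 4 `COc1cc(-c2nnc3n2NC(c2ccco2)C(C(=O)c2ccco2)S3)cc(OC)c1OC` changes compound 1 at the same place: furan-2-yl in place of 4-chlorophenyl on a carbonyl carbon. For the measured compounds named here, the only step available thus concerns the same carbonyl carbon, and its floor lies within the scatter, so for compound 4 a number near that of compound 1, or a further drift toward the limit, is expected, which is the step of a 1.6-fold higher number from compound 1 to compound 4 (0.19 log units; within the scatter). Compound 4 is accordingly estimated at 80000 nM, expected to fall between 30000 nM and 200000 nM.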

Compound 4, half-maximal inhibitory concentration: 68700 nM
For compound 4 the middle estimate is 1.2-fold (0.07 log units) above the measured one, and the stated range covers the measured number.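

On the carbonyl carbon, furan-2-yl takes the place of 4-chlorophenyl and, in this assay, the result is a 1.3-fold higher number from compound 1 to compound 4 (0.13 log units; within the scatter), so these two aromatic groups cannot be told apart in this series. The position now holds a second measured number, and compound 4 shows that a reading under the limit does not depend on the chlorine atom or on a six-membered aromatic ring of carbon only. Set against the cyclopropyl group, the result is an at least 1.4-fold lower number from compound 2 to compound 4 (0.16 log units; that floor lies within the scatter), but this is a floor only and the true size of the step remains unknown: the limit of > 100000 nM in this assay, at which 2 of the 4 values shown sit.

The compounds shown leave open whether any group on this carbonyl carbon can move the number well away from those of compound 1 and compound 4, as an amine or a carboxylic acid carried on the aromatic ring might or might not do. Compound 3 differs from compound 1 in more than one place, so it cannot settle what the furan-2-yl group on the shared core contributes.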